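A Chloro Group Returns to the Benzyl Arm at a New Place

The source may report more compounds than this note shows. Statements on the series, on what has been measured and on what is new or still open speak of the compounds shown alone.

Compound 1 `Cc1cc(S(=O)(=O)/N=C(\N)n2nccc2-c2ccccc2)c(SCc2ccc(Cl)cc2)cc1Cl`: 3000 nM in a functional assay on HeLa cells (Homo sapiens) for cytotoxicity, read by MTT assay, with a stated time of 72 h; a lower number here means a stronger inhibitor, a higher number a weaker inhibitor
Compound 2 `Cc1cc(S(=O)(=O)/N=C(\N)n2nccc2-c2ccccc2)c(SCc2ccc(C(F)(F)F)cc2)cc1Cl`: 17000 nM
Compound 3 `Cc1cc(S(=O)(=O)/N=C(\N)n2nccc2-c2ccccc2)c(SCc2ccccc2C)cc1Cl`: 17000 nM

Compound 3 sits level with compound 2 as far as the figures go, and the two share the highest number of the three; compound 1 stands apart by the step of a 5.7-fold higher number from compound 1 to compound 3 (0.75 log units; beyond the scatter). Compound 4 `Cc1cc(S(=O)(=O)/N=C(\N)n2nccc2-c2ccccc2)c(SCc2cccc(Cl)c2)cc1Cl` differs from compound 3 by 3-chlorophenyl in place of 2-methylphenyl on a saturated chain carbon bound to a sulfur. Going by the values given here, two measured steps bear on this: a 5.7-fold higher number from compound 1 to compound 3 (0.75 log units; beyond the scatter) shows a chlorophenyl giving the lower number, while no change at the digits printed from compound 2 to compound 3 (within the scatter) shows no movement. Among the compounds with values here, no measured pair tests a 3-chlorophenyl, so the weight lies on the first step. A modest fall in this assay is therefore expected, a 2.1-fold lower number from compound 3 to compound 4 (0.33 log units; beyond the scatter). Compound 4 is estimated at 8000 nM, with a range from 3000 nM to 22000 nM.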

Compound 4, half-maximal inhibitory concentration: 10000 nM
For compound 4 the middle estimate is 1.3-fold (0.10 log units) below the measured one; measured number inside the range.
By their numbers in this assay, from the lowest: compound 1; then compounds 4, 2 and 3 (each within the scatter of the next).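

With the chloro group kept on the benzyl arm, a 3.3-fold higher number from compound 1 to compound 4 (0.52 log units; beyond the scatter) shows that in this assay 3-chlorophenyl and 4-chlorophenyl are not interchangeable at this place on a saturated chain carbon bound to a sulfur. Having a chloro group is thus not enough to match compound 1, since a 1.7-fold lower number from compound 3 to compound 4 (0.23 log units; within the scatter) and a 1.7-fold lower number from compound 2 to compound 4 (0.23 log units; within the scatter) both lie within the scatter. No evidence is available to explain this difference. The compounds shown leave open how 2-chlorophenyl would read at this place. They also leave open how a phenyl ring bearing a methoxy group or an amine would read there.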